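The source may report more compounds than this note shows. Statements on the series, on what has been measured and on what is new or still open speak of the compounds shown alone.

compound 1 `O=S(=O)(/C=C/c1ccc(O)c(O)c1)CCCCCCCCO`: 6700 nM
compound 2 `O=S(=O)(/C=C/c1ccc(O)c(O)c1)CCCCCCCO`: 5900 nM
compound 3 `CCCCCCCCCS(=O)(=O)/C=C/c1ccc(O)c(O)c1`: 7700 nM

In a functional assay, read by fluorescence and spectrophotometry, with a stated time of 1 h (on this read-out higher numbers stand for an effect only at larger amounts of compound and lower numbers for an effect already at smaller amounts), compound 3 gives 7700 nM, which lies within the scatter of both other values: a 1.1-fold higher number from compound 1 to compound 3 (0.06 log units; within the scatter) and a 1.3-fold higher number from compound 2 to compound 3 (0.12 log units; within the scatter).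

Next is compound 4 `O=S(=O)(/C=C/c1ccc(O)c(O)c1)CCCCCCCCCCCO`, with 2-hydroxyethyl in place of hydrogen on a saturated chain carbon, nine bonds along the chain from a sulfonyl sulfur. This places 2-hydroxyethyl in place of hydrogen on a saturated chain carbon, nine bonds along the chain from a sulfonyl sulfur.

The closest precedents are a 1.1-fold higher number from compound 1 to compound 3 (0.06 log units; within the scatter), which exchanges methyl for hydroxy, and a 1.1-fold lower number from compound 1 to compound 2 (0.06 log units; within the scatter), which removes chain length from a hydroxy-ended compound. Both stay within the scatter. Among the measured compounds shown here, no measured compound carries a chain as long as that of compound 4, so this is an extrapolation.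

The step of a 1.3-fold lower number from compound 3 to compound 4 (0.11 log units; within the scatter) is therefore expected to stay within the scatter. The estimate for compound 4 is 6000 nM, with an expected range of 2800 nM to 13000 nM.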

Compound 4, half-maximal effective concentration: 22600 nM
Compound 4: the middle estimate sits 3.8-fold (0.58 log units) below what was measured, outside the stated range (above it).
By their numbers in this assay, from the lowest: compounds 2, 1 and 3 (each within the scatter of the next); then compound 4.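

In this assay, among the compounds shown here, 2-hydroxyethyl in place of hydrogen on a saturated chain carbon, nine bonds along the chain from a sulfonyl sulfur, is the first change to go beyond the scatter: a 2.9-fold higher number from compound 3 to compound 4 (0.47 log units; beyond the scatter). The hydroxy-ended compounds agree, with a 3.4-fold higher number from compound 1 to compound 4 (0.53 log units; beyond the scatter) and a 3.8-fold higher number from compound 2 to compound 4 (0.58 log units; beyond the scatter), so here the longest hydroxy-ended chain carries the highest number, although compound 1 and compound 2 lie within the scatter of each other. No available evidence bears on this result. Whether chain length or the end hydroxy accounts for the step stays open. A plain alkyl chain of that length, or a carboxylic acid or an amine at the chain end, would help separate the two.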